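The source may hold more compounds than are shown below. What is called first, only, known or untested is meant among the compounds shown, and "the series" means these compounds.

Working notes on the series.

Compound 1 `COc1cc2c(Oc3ccc(NC(=O)c4cn(-c5ccc(Cl)cc5)cn4)cc3F)ccnc2cc1OCCCN1CCN(C)CC1` and compound 2 `COc1cc2c(Oc3ccc(NC(=O)c4cn(-c5ccc(Cl)cc5)cn4)cc3F)ccnc2cc1OCCCN1CCCCC1` share one core and differ only in the basic ring at the end of the chain. In a functional assay on A549 cells (Homo sapiens) for cytotoxicity, read by MTT assay, with a stated time of 72 h (on this read-out lower numbers stand for stronger inhibition and higher numbers for weaker inhibition), compound 1 gives 5200 nM, and in this assay compound 2 gives 6560 nM. The change between them is piperidin-1-yl in place of 4-methylpiperazin-1-yl on a saturated chain carbon, three bonds along the chain from an oxygen on an aromatic ring and the step it made is a 1.3-fold higher number from compound 1 to compound 2 (0.10 log units; within the scatter).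

Compound 3 `COc1cc2c(Oc3ccc(NC(=O)/C=C/S(=O)(=O)c4ccccc4OC)cc3F)ccnc2cc1OCCCN1CCN(C)CC1` carries a different amide part on the same aryl ether; the difference between its core and the core of compound 1 is not broken down here. In this assay, within the data shown here, compound 3 gives 320 nM, the lowest of the three numbers so far, and its distance from compound 1 and compound 2 lies beyond the scatter.

Compound 4 `COc1cc2c(Oc3ccc(NC(=O)/C=C/S(=O)(=O)c4ccccc4OC)cc3F)ccnc2cc1OCCCN1CCCCC1` is not yet measured. It stands to compound 3 as compound 2 stands to compound 1: the change is piperidin-1-yl in place of 4-methylpiperazin-1-yl on a saturated chain carbon, three bonds along the chain from an oxygen on an aromatic ring, the same change as before, at the same place on the chain. On the core of compound 1 this change moved the number only within the scatter, as seen in a 1.3-fold higher number from compound 1 to compound 2 (0.10 log units; within the scatter). The expected step in this assay is therefore a 1.3-fold higher number from compound 3 to compound 4 (0.12 log units; within the scatter), resting on the step from compound 1 to compound 2, with no further evidence that the new core would answer differently. Compound 4 is thus estimated at 420 nM in this assay, with the range expected to run from 200 nM to 900 nM.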

Compound 4, half-maximal inhibitory concentration: 470 nM
Beside the measured number, compound 4's estimate is 1.1-fold (0.05 log units) below it, and the stated range covers the measured number.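

In this assay, piperidin-1-yl in place of 4-methylpiperazin-1-yl on the core of compound 3 gives a 1.5-fold higher number from compound 3 to compound 4 (0.17 log units; within the scatter), so on this second core too the change stays within the scatter. The change therefore carries across the two cores shown, and the size of its step on one core serves as a fair guide to its step on the other, with no difference between them that can be told from the scatter: the same change on two cores in this assay, a 1.3-fold higher number (0.10 log units; within the scatter) from compound 1 to compound 2 and a 1.5-fold higher number (0.17 log units; within the scatter) from compound 3 to compound 4, 1.2-fold (0.07 log units) apart, within the scatter of two such steps This shows only that the change is equally small on these two cores, at this one place on the chain and in this one cell assay; it does not show that the change would stay this small on other cores or in other assays, and it gives no reason for the small size of either step.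

Open, going by these compounds, is whether a morpholin-4-yl ring or a dimethylamino group in the same place, or a longer chain carrying either ring, would fit the same picture on both cores. Also open, on these data alone, is whether the change would hold on a core whose amide part carries a plain phenyl group.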